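Fluoro for chloro: from compound 3 to compound 4

A few compounds are considered here, and "the series" means these few. Any claim that something is new, unique, unknown or untested is made for them only; others in the source may bear on it.

Among the compounds with values here, in an ADME assay on HEK293 cells (Homo sapiens) for cytotoxicity, with a stated time of 72 h (a higher number here means that more compound is needed for the effect, a lower number that less compound is needed), compound 3 (`COc1ccc(NC(=O)Nc2cc(C)nc3ccccc23)cc1Cl`) gives 26000 nM as the only number in the set. Compound 1 (`COc1ccc(NC(=O)Nc2cc(C)nc3ccccc23)cc1OC`) reads > 25000 nM and this is a limit only. Compound 2 (`Cc1cc(NC(=O)Nc2ccc(F)c(F)c2)c2ccccc2n1`) reads > 25000 nM and this too is a limit only. Compound 4 (`COc1ccc(NC(=O)Nc2cc(C)nc3ccccc23)cc1F`) differs from compound 3 by fluoro in place of chloro on an aromatic carbon. Within the data shown here, one measured step bears on this change: a step that the limit leaves unreadable from compound 1 to compound 3 and it offers no size to carry over. No step beyond the scatter is therefore expected in this assay and no direction can be given. The result for compound 4 may also fall on the limit of > 25000 nM in this assay, at which 2 of the 3 values shown sit, and give no number. The estimate means a 1.1-fold higher number from compound 3 to compound 4 (0.03 log units; within the scatter) as an expected step within the scatter. Compound 4 is estimated at 28000 nM with an expected range from 15000 nM to 50000 nM for a numeric reading.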

Compound 4, half-maximal effective concentration: > 25000 nM
Compound 4: no number, only a limit; the forecaster's own chance of this, stated with the estimate: 55%; the middle value lies beyond the limit too.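

In this assay, within the data shown here, compound 4 gives > 25000 nM, a limit and not a number, so no step between compound 4 and compound 1, compound 2 or compound 3 can be read: the limit of > 25000 nM in this assay, at which 3 of the 4 values shown sit. The compounds shown leave open whether fluoro, chloro or methoxy on this aromatic carbon shifts the reading at all.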